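Nitrogen substituent of the shared core: isopropyl to sec-butyl

This account rests on a few compounds, and the source may have more. Where it says the series, first, only, none or still open, it means among the compounds named here.

In an assay on HEK293 cells for activation of Kir3.1/Kir3.2 (Homo sapiens), read by thallium flux (on this read-out lower numbers stand for an effect already at smaller amounts and higher numbers for an effect only at larger amounts of compound), compound 3 `Cc1cc(NC(=O)Cn2nnc(-c3ccccc3)n2)n(C(C)C)n1` gives 556 nM, the higher of the two numbers shown, while compound 1 `Cc1cc(NC(=O)Cn2nnc(-c3ccccc3)n2)n(C2CCOCC2)n1` gives 435 nM, and a 1.3-fold higher number from compound 1 to compound 3 (0.11 log units; within the scatter) lies within the scatter. Compound 2 `Cc1cc(NC(=O)Cn2nnc(-c3ccccc3)n2)n(C2CCC(C)(C)CC2)n1` is reported only as a limit, > 221 nM. Because of the limit of > 221 nM in this assay, at which 1 of the 3 values shown sits, the steps a step that the limit leaves unreadable from compound 1 to compound 2 and a step that the limit leaves unreadable from compound 2 to compound 3 cannot be read. Compound 4 `CCC(C)n1nc(C)cc1NC(=O)Cn1nnc(-c2ccccc2)n1` differs from compound 3 by methyl in place of hydrogen on a saturated chain carbon, two bonds along the chain from an aromatic nitrogen. Among the measured compounds shown here, the only readable step at this nitrogen substituent, a 1.3-fold higher number from compound 1 to compound 3 (0.11 log units; within the scatter), is small, and the step toward the larger substituent of compound 2 stays unreadable. A step of similar small size, within the scatter, is therefore expected, and a 1.0-fold lower number from compound 3 to compound 4 (0.00 log units; within the scatter) is the estimate. Compound 4 is expected to give about 550 nM, between 220 nM and 1400 nM.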

Compound 4, half-maximal effective concentration: > 5000 nM
Compound 4: no number, only a limit; the forecaster's own chance of this, stated with the estimate: 10%; at least 9.0-fold (0.95 log units) between middle value and limit.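

In this assay compound 4 is reported only as a limit, > 5000 nM. A single added methyl at this nitrogen substituent can therefore shift the read-out beyond the scatter: methyl in place of hydrogen on a saturated chain carbon, two bonds along the chain from an aromatic nitrogen, gives an at least 8.9-fold higher number from compound 3 to compound 4 (0.95 log units; beyond the scatter), and sec-butyl in place of oxan-4-yl gives an at least 11-fold higher number from compound 1 to compound 4 (1.06 log units; beyond the scatter), although the earlier isopropyl and oxan-4-yl pair stayed within the scatter. The step involving the two limits, compound 2 and compound 4, cannot be read.

From the compounds shown here alone, whether an unbranched propyl or a cyclopropyl group on this nitrogen stays near compound 3 remains open. Going by these compounds, the full size of the change also remains open.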